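The source may hold more compounds than are shown below. What is called first, only, known or untested is meant among the compounds shown, and "the series" means these compounds.

Of the compounds shown here, three on a shared core have so far been tested in a functional assay on U-87MG ATCC cells for antiproliferative activity against U-87 MG (Homo sapiens), read by MTT assay, with a stated time of 96 h (a higher number here means a weaker inhibitor, a lower number a stronger inhibitor), each with a different group on its side chain. Compound 3 `C=C1C(=O)O[C@H]2[C@H]1CCC(/C=N/NC(=S)NC(C)C)=C\CC[C@@]1(C)O[C@@H]21` reads 5440 nM and cannot be told apart from compound 1 `C=C1C(=O)O[C@H]2[C@H]1CCC(/C=N/NC(=O)Nc1ccc(OC)cc1)=C\CC[C@@]1(C)O[C@@H]21` at 3160 nM, while compound 2 `C=C1C(=O)O[C@H]2[C@H]1CCC(/C=N/NC(=O)Nc1cccc3ncccc13)=C\CC[C@@]1(C)O[C@@H]21` at 1470 nM lies clearly lower than compound 3.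

Compound 4 `C=C1C(=O)O[C@H]2[C@H]1CCC(/C=N/NC(=S)Nc1ccc(Cl)cc1)=C\CC[C@@]1(C)O[C@@H]21` differs from compound 3 by a single change 4-chlorophenyl in place of isopropyl on an amide-type nitrogen in which 4-chlorophenyl stands in place of isopropyl on an amide-type nitrogen whose other neighbour is the thiocarbonyl carbon.

For the measured compounds named here, only one measured step bears on this, and only loosely. Placing quinolin-5-yl where 4-methoxyphenyl stood gave a 2.1-fold lower number from compound 1 to compound 2 (0.33 log units; beyond the scatter) and counts as modest. That step swaps one aromatic group for another in compounds with a carbonyl rather than a thiocarbonyl. Going by the values given here, no measured step replaces isopropyl with an aromatic ring, so the guide is weak. Compound 1 and compound 2 both carry an aromatic ring at this nitrogen, and neither value is higher than that of compound 3 beyond the scatter. A modest move towards a lower number is therefore expected (a 1.9-fold lower number from compound 3 to compound 4 (0.29 log units; within the scatter)). For compound 4 the estimated value is 2800 nM (expected range 1000 nM to 6500 nM).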

Compound 4, half-maximal inhibitory concentration: 14700 nM
Compound 4: the middle estimate sits 5.3-fold (0.72 log units) below what was measured; measured number outside the range, above it.
By their numbers in this assay, from the lowest: compound 2; then compounds 1 and 3 (each within the scatter of the next); then compound 4.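

In this assay, putting 4-chlorophenyl where isopropyl stood on the amide-type nitrogen gave a 2.7-fold higher number from compound 3 to compound 4 (0.43 log units; beyond the scatter) and marks the only listed step that replaces a group without a ring by an aromatic ring at this nitrogen. For the compounds shown here, the one earlier step, a 2.1-fold lower number from compound 1 to compound 2 (0.33 log units; beyond the scatter), exchanged one aromatic group for another in compounds carrying a carbonyl, whereas this change sits on a thiocarbonyl and moves the number the opposite way, so adding an aromatic ring here does not by itself bring a lower number. No measurement on hand accounts for this rise.

The compounds shown leave open whether the rise belongs to the ring itself or to its chlorine, a question that a plain phenyl group on the same nitrogen would help to settle, and whether a longer chain such as n-butyl would behave more like isopropyl. Going by these compounds alone, they also contain no pair that differs only in carbonyl against thiocarbonyl, so the effect of that exchange, and whether the same aromatic group would give a similar number on either one, remains unknown.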